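Pyrrole to chlorofuran on the acrylamide chain

The source may report more compounds than this note shows. Statements on the series, on what has been measured and on what is new or still open speak of the compounds shown alone.

Compound 1 (`COc1ccc(CNC(=O)/C(C#N)=C/c2ccc[nH]2)cc1`) was tested in a functional assay on MIA cells (Homo sapiens) for inhibition, read by MTT assay, with a stated time of 72 h; on this read-out higher numbers stand for weaker inhibition of growth and lower numbers for stronger inhibition of growth. In this assay compound 1 gives only a limit, > 50000 nM, and no number. Compound 2 (`N#C/C(=C\c1ccc[nH]1)C(=O)NCc1ccc(Cl)c(Cl)c1`) was tested in the same assay. In this assay compound 2 likewise gives only a limit, > 50000 nM. Among the measured compounds shown here, both values shown therefore sit at the limit, as the limit of > 50000 nM in this assay, at which 2 of the 2 values shown sit, states, so compound 1 stands at the limit alongside the only other measured compound, with no ordering between them possible.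

Compound 3 (`COc1ccc(CNC(=O)/C(C#N)=C/c2ccc(Cl)o2)cc1`) has not yet been measured in this assay. It differs from compound 1 in one place: 5-chlorofuran-2-yl in place of 1H-pyrrol-2-yl on a double-bonded chain carbon bound to a double-bonded chain carbon. For the measured compounds named here, no step between measured compounds is available to guide the direction or size of this change, and both measured compounds sit at the limit.

Compound 3 is therefore expected to remain at or near the limit, with an estimated step of a number no higher from compound 1 to compound 3 (the limit leaves the size open) of no size beyond the scatter. Compound 3 is estimated at 50000 nM, with a range from 15000 nM to 150000 nM.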

Compound 3, concentration for 50% growth inhibition: 15000 nM
Compound 3: middle estimate off by 3.3-fold (0.52 log units), on the high side; the range from low to high includes it.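

In this assay, 5-chlorofuran-2-yl in place of 1H-pyrrol-2-yl on a double-bonded chain carbon bound to a double-bonded chain carbon gives an at least 3.3-fold lower number from compound 1 to compound 3 (0.52 log units; beyond the scatter). This shows that a change at this place can bring a compound in this series to a measured number, which compound 1 and compound 2 could not show, as each gives only a limit. The step has a known lower bound but no known full size, as its starting point is a limit: the limit of > 50000 nM in this assay, at which 2 of the 3 values shown sit.

The change alters the ring hetero atom and adds chlorine in a single step, so the compounds shown cannot divide the step between the two. Also open, as far as these compounds go, are how an unsubstituted furan-2-yl or a 5-bromofuran-2-yl group would read at this place, and whether the same change would carry over to the core of compound 2.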